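Swapping an Ester for a Nitro Group

This account rests on a few compounds, and the source may have more. Where it says the series, first, only, none or still open, it means among the compounds named here.

Three biphenyl-type compounds have been measured in an assay on COS-7 cells for inhibition of patatin-like phospholipase domain-containing protein 2 (Mus musculus), tested at 200 uM; a higher number here means more inhibition at the concentration tested (going by the name of the read-out), a lower number less inhibition. Compound 1 `CCOC(=O)c1cccc(-c2ccc(O)cc2)c1` gives 77%, compound 2 `CCOC(=O)c1cccc(-c2ccc(OC)cc2)c1` gives 77%, and compound 3 `CCOC(=O)c1cccc(-c2ccc(N(C)C)cc2)c1` gives 87%. The steps of no change at the digits printed from compound 1 to compound 2 (within the scatter), a number 10 percentage points higher from compound 1 to compound 3 (within the scatter) and a number 10 percentage points higher from compound 2 to compound 3 (within the scatter) all lie within the scatter, so the three numbers cannot be told apart. Compound 4 `CN(C)c1ccc(-c2cccc([N+](=O)[O-])c2)cc1` differs from compound 3 by nitro in place of ethoxycarbonyl on an aromatic carbon. Within the data shown here, none of the measured steps touches this part of the molecule; they all change the group on the other ring. There is thus no direct guide, and the expectation rests on the shared core alone. Compound 4 is expected to give about 70%, between 40% and 95%. The expected step is a number 17 percentage points lower from compound 3 to compound 4 (beyond the scatter).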

Compound 4, a percentage reported as inhibition, at one concentration (the size of the read-out at that concentration, not a potency): 21%
Compound 4: the middle estimate sits 49 percentage points above what was measured; the whole stated range lies above it.
By their numbers in this assay, from the lowest: compound 4; then compounds 1, 2 and 3 (each within the scatter of the next).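

Among these compounds, the earlier steps all changed the group on the other ring and stayed within the scatter, so this is the first clear sign that the place holding the ethoxycarbonyl matters: in this assay, nitro in place of ethoxycarbonyl gives a number 66 percentage points lower from compound 3 to compound 4 (beyond the scatter) and a result beyond anything seen so far. The two groups have equal counts of hydrogen-bond donors and acceptors, yet the numbers part widely. Nothing measured here explains the drop.

From the compounds shown here alone, whether a carboxylic acid, an amide or a longer ester at this place would keep the number stays open. So does whether the same swap would act alike with hydroxy or methoxy on the other ring.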